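This account rests on a few compounds, and the source may have more. Where it says the series, first, only, none or still open, it means among the compounds named here.

The measured compounds and their values:

Compound 1, `C[Se]/C(=N\C(=O)c1cc2ccccc2s1)NC(=O)c1cc2ccccc2s1`: 5070 nM
Compound 2, `CS/C(=N\C(=O)c1cc2ccccc2s1)NC(=O)c1cc2ccccc2s1`: 9510 nM
Compound 3, `C[Se]/C(=N\C(=O)c1cnc2ccccc2c1)NC(=O)c1cnc2ccccc2c1`: 660 nM

All three were tested in a functional assay on MCF7 cells (Homo sapiens) for cytotoxicity, read by MTT assay, with a stated time of 72 h; on this read-out lower numbers stand for stronger inhibition of growth and higher numbers for weaker inhibition of growth. In this assay compound 3 gives 660 nM, the lowest number of the three, and its gaps to compound 1 and to compound 2 are both beyond the usual scatter, so among the measured compounds it is the most potent. Compound 1 and compound 2 share one core, while compound 3 is built on a different core; the difference between the two cores is not broken down here.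

Compound 1 and compound 2 differ in one place only: a group of 2 heavy atoms (1 carbon, 1 sulfur; no ring) in place of a group of 2 heavy atoms (1 carbon, 1 selenium; no ring), on a carbon with a double bond to nitrogen. That change gave a 1.9-fold higher number from compound 1 to compound 2 (0.27 log units; within the scatter), a step that lies within the scatter of repeated measurements.

Compound 4, `CS/C(=N\C(=O)c1cnc2ccccc2c1)NC(=O)c1cnc2ccccc2c1`, has not yet been measured. It stands to compound 3 exactly as compound 2 stands to compound 1, since (a group of 2 heavy atoms (1 carbon, 1 sulfur; no ring) in place of a group of 2 heavy atoms (1 carbon, 1 selenium; no ring), on a carbon with a double bond to nitrogen), and the surroundings of the changed position read the same in both pairs, so this is the same change made on the other core. The expectation for compound 4 therefore rests on compound 1 and compound 2, where the step was a 1.9-fold higher number from compound 1 to compound 2 (0.27 log units; within the scatter). On that basis a step of a 1.7-fold higher number from compound 3 to compound 4 (0.22 log units; within the scatter) is expected, again within the scatter. In this assay compound 4 is estimated to give 1100 nM, with a likely range from 500 nM to 2600 nM.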

Compound 4, concentration for 50% growth inhibition: 23900 nM
Compound 4: middle estimate off by 22-fold (1.34 log units), on the low side, outside the stated range (above it).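

In this assay, putting methylsulfanyl in place of the selenium-bearing group on the core of compound 3 gave a 36-fold higher number from compound 3 to compound 4 (1.56 log units; beyond the scatter), a large step that is clearly more than assay noise. Set beside the same swap on the other core, this step does not match the earlier one: the same change on two cores in this assay, a 1.9-fold higher number (0.27 log units; within the scatter) from compound 1 to compound 2 and a 36-fold higher number (1.56 log units; beyond the scatter) from compound 3 to compound 4, 19-fold (1.29 log units) apart, beyond the scatter of two such steps This shows that in this series the swap does not carry a fixed size from one core to another, so the small step seen on the core of compound 1 was a poor guide to the step on the core of compound 3, although it does not show why the two cores differ, and two pairs in a single assay cannot establish a general rule.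

The compounds shown leave open how the swap would behave on a third core, and whether the gap between the two cores would hold in a cell line other than this one. They also leave open whether a longer chain on the selenium or the sulfur, or an amine in place of either group on that carbon with a double bond to nitrogen, would keep the number of compound 3, which gives 660 nM.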